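Stripping the aromatic substituent: compound 3 to compound 4

The source may report more compounds than this note shows. Statements on the series, on what has been measured and on what is new or still open speak of the compounds shown alone.

Three members of the series have numbers in a functional assay on SW-620 cells (Homo sapiens) for antiproliferative activity, read by MTT assay, with a stated time of 72 h; on this read-out lower numbers stand for stronger inhibition and higher numbers for weaker inhibition. Compound 1 `CC(C)(C)c1cn(C[C@H](O)[C@H]2OC(=O)C(OCc3ccccc3)=C2OCc2ccccc2)nn1` gives 35800 nM in this assay. Compound 2 `O=C1O[C@H]([C@@H](O)Cn2cc(CNS(=O)(=O)c3ccc(F)cc3)nn2)C(OCc2ccccc2)=C1OCc1ccccc1` gives 41100 nM, and compound 3 `CCCCCc1ccc(-c2cn(C[C@H](O)[C@H]3OC(=O)C(OCc4ccccc4)=C3OCc3ccccc3)nn2)cc1` gives 12200 nM. Compound 3 stands lowest of the three: the step of a 2.9-fold lower number from compound 1 to compound 3 (0.47 log units; beyond the scatter) and the step of a 3.4-fold lower number from compound 2 to compound 3 (0.53 log units; beyond the scatter) both lie beyond the scatter, while the step of a 1.1-fold higher number from compound 1 to compound 2 (0.06 log units; within the scatter) does not.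

Compound 4 `O=C1O[C@H]([C@@H](O)Cn2ccnn2)C(OCc2ccccc2)=C1OCc1ccccc1` is not yet measured. It differs from compound 3 as follows: hydrogen in place of 4-pentylphenyl on an aromatic carbon. The change sits on an aromatic carbon of a five-membered aromatic ring with 3 nitrogen, the same place where compound 1 carries tert-butyl and compound 2 carries (((4-fluorophenyl)sulfonyl)amino)methyl.

Within the data shown here, no measured step removes a group at this place altogether, so the bearing steps are indirect. Both replacements of a smaller group by 4-pentylphenyl, from compound 1 and from compound 2, gave a modest move to lower numbers. Taking the group away entirely is expected to reverse that move, and a step at least the size of those two is expected for compound 4, toward higher numbers: a 3.7-fold higher number from compound 3 to compound 4 (0.57 log units; beyond the scatter). The estimate for compound 4 in this assay is 45000 nM, with a range from 20000 nM to 100000 nM. Whether hydrogen ends near the tert-butyl of compound 1 or further up cannot be told from the three numbers.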

Compound 4, half-maximal inhibitory concentration: > 100000 nM
Compound 4: only a limit was reported; the forecaster's own chance of this, stated with the estimate: 15%; at least 2.2-fold (0.34 log units) between middle value and limit.
By their numbers in this assay, from the lowest: compound 3; then compounds 1 and 2 (each within the scatter of the next). At a limit, above all of these: compound 4.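

Compound 4 in this assay is reported only as a limit, > 100000 nM, so the steps to it give lower bounds on size and not sizes: the limit of > 100000 nM in this assay, at which 1 of the 4 values shown sits.

Among these compounds, the earlier compounds showed only one group exchanged for another on this aromatic carbon of the five-membered aromatic ring with 3 nitrogen, whereas hydrogen now gives a reference point, and each of the three groups stands clearly apart from it: an at least 8.1-fold higher number from compound 3 to compound 4 (0.91 log units; beyond the scatter), an at least 2.4-fold higher number from compound 2 to compound 4 (0.38 log units; beyond the scatter) and an at least 2.7-fold higher number from compound 1 to compound 4 (0.44 log units; beyond the scatter). Tert-butyl and (((4-fluorophenyl)sulfonyl)amino)methyl, which could not be separated from each other in this assay, thus both count as lower-number substituents relative to hydrogen, though how far cannot be read from a limit.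

The compounds shown leave open how small a group at this place is enough to bring the number down from the limit, which a methyl or an amine would test. They also do not separate the aromatic ring of 4-pentylphenyl from its chain, a question that an unsubstituted phenyl and a longer chain on that ring would address.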